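Urea-linked anilinoquinazoline series: swapping the urea aryl group

A few compounds are considered here, and "the series" means these few. Any claim that something is new, unique, unknown or untested is made for them only; others in the source may bear on it.

Measured so far:
- compound 1 `CC(C)(C)c1ccc(NC(=O)Nc2cccc(CNc3ncnc4ccccc34)c2)cc1`: 17900 nM
- compound 2 `O=C(Nc1cccc(CNc2ncnc3ccccc23)c1)Nc1ccccc1F`: 26100 nM
- compound 3 `COc1cc2ncnc(NCc3cccc(NC(=O)Nc4ccc(C(C)(C)C)cc4)c3)c2cc1OC`: 5210 nM

All three values come from a functional assay on A549 cells (Homo sapiens) for antiproliferative activity, read by MTT assay; on this read-out higher numbers stand for weaker inhibition and lower numbers for stronger inhibition. Compound 1 and compound 2 share one core and differ only by 2-fluorophenyl in place of 4-(tert-butyl)phenyl on an amide-type nitrogen; the step of a 1.5-fold higher number from compound 1 to compound 2 (0.16 log units; within the scatter) is small and gives no ground to order the two. Compound 3 carries a different core; how it differs from the core of compound 1 is not broken down here. In this assay compound 3 gives the lowest of the three numbers, and its gaps to compound 1 and to compound 2 lie beyond the scatter.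

Compound 4 `COc1cc2ncnc(NCc3cccc(NC(=O)Nc4ccccc4F)c3)c2cc1OC` is not yet measured. It is made from compound 3 by 2-fluorophenyl in place of 4-(tert-butyl)phenyl on an amide-type nitrogen, the same kind of change as that from compound 1 to compound 2; the place is described in the same words in both pairs. Among the compounds with values here, the one measured instance of this change, a 1.5-fold higher number from compound 1 to compound 2 (0.16 log units; within the scatter), stayed within the scatter. On that single precedent the step from compound 3 to compound 4 is expected to be a 1.4-fold higher number from compound 3 to compound 4 (0.16 log units; within the scatter), small, with a wide range because the comparison rests on one pair and a different core. Compound 4 is accordingly estimated at 7500 nM in this assay.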

Compound 4, half-maximal inhibitory concentration: 23800 nM
For compound 4 the middle estimate is 3.2-fold (0.50 log units) below the measured one, and the stated range ends below it.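

In this assay, 2-fluorophenyl in place of 4-(tert-butyl)phenyl on the amide-type nitrogen gives a 4.6-fold higher number from compound 3 to compound 4 (0.66 log units; beyond the scatter), so the change does not carry over at one size from the core of compound 1 to the core of compound 3: the same change on two cores in this assay, a 1.5-fold higher number (0.16 log units; within the scatter) from compound 1 to compound 2 and a 4.6-fold higher number (0.66 log units; beyond the scatter) from compound 3 to compound 4, 3.1-fold (0.50 log units) apart, beyond the scatter of two such steps Within these four compounds, a step measured on one core is therefore a poor guide to the same step on the other. This comparison rests on one pair per core and shows only that the size of the step differs between these two cores; it does not show which feature of the core is responsible, or how any other aryl group would behave.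

Still open, on these data alone, is whether the two cores also part ways for other groups on the amide-type nitrogen, such as an unsubstituted phenyl or a cyclohexyl group. Such pairs would show whether this gap is specific to the exchange of 4-(tert-butyl)phenyl for 2-fluorophenyl or holds more widely across the series.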